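Changing 4-iodophenyl to 3-chlorophenyl on an amine nitrogen

This account rests on a few compounds, and the source may have more. Where it says the series, first, only, none or still open, it means among the compounds named here.

Values so far in a functional assay on HeLa cells (Homo sapiens) for inhibition, read by sulforhodamine B assay (a lower number here means a stronger inhibitor, a higher number a weaker inhibitor), are these
- Compound 1 `Cc1ccc(NC2=CC(=O)c3nc4n(c3C2=O)[C@H]2OC[C@@H](O)[C@H]2OC4)cc1C` gives 2690 nM
- Compound 2 `O=C1C=C(Nc2ccccc2)C(=O)c2c1nc1n2[C@H]2OC[C@@H](O)[C@H]2OC1` gives 5620 nM
- Compound 3 `O=C1C=C(Nc2ccc(I)cc2)C(=O)c2c1nc1n2[C@H]2OC[C@@H](O)[C@H]2OC1` gives 4070 nM

These three compounds share one core and differ only in the group on the amine nitrogen. Compound 3 stands inside the narrow range set by the other two, with a 1.5-fold higher number from compound 1 to compound 3 (0.18 log units; within the scatter) and a 1.4-fold lower number from compound 2 to compound 3 (0.14 log units; within the scatter) as its two steps.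

The next compound is compound 4 `O=C1C=C(Nc2cccc(Cl)c2)C(=O)c2c1nc1n2[C@H]2OC[C@@H](O)[C@H]2OC1`, which carries 3-chlorophenyl in place of 4-iodophenyl on an amine nitrogen. Among the compounds with values here, no measured step makes this exact swap, and no measured compound carries a chloro group, so the guide is indirect. The largest change seen on this nitrogen is a 2.1-fold higher number from compound 1 to compound 2 (0.32 log units; beyond the scatter), and adding iodo to the plain phenyl of compound 2 gave only a 1.4-fold lower number from compound 2 to compound 3 (0.14 log units; within the scatter). Changes at this position have so far moved the numbers little, though three compounds are a thin base.

In this assay no shift beyond the scatter is therefore expected, and the estimated change is a 1.1-fold lower number from compound 3 to compound 4 (0.03 log units; within the scatter). The estimate for compound 4 is 3800 nM (expected range 1900 nM to 7500 nM).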

Compound 4, half-maximal inhibitory concentration: 6040 nM
Compound 4: the middle estimate sits 1.6-fold (0.20 log units) below what was measured, and the stated range covers the measured number.
By their numbers in this assay, from the lowest: compounds 1, 3, 2 and 4 (each within the scatter of the next, the first and the last beyond it).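

In this assay, the swap of 4-iodophenyl for 3-chlorophenyl gives a 1.5-fold higher number from compound 3 to compound 4 (0.17 log units; within the scatter) and adding chloro to the plain phenyl gives a 1.1-fold higher number from compound 2 to compound 4 (0.03 log units; within the scatter) so neither halogen-bearing ring stands apart from the plain phenyl on this amine nitrogen. The only gap beyond the scatter in the new steps again starts from the 3,4-dimethylphenyl group, with a 2.2-fold higher number from compound 1 to compound 4 (0.35 log units; beyond the scatter) so compound 1 now differs from both compound 2 and compound 4, while compound 3 remains within the scatter of all three others. Nothing available explains these differences.

This swap changes both the halogen and its place on the ring, so the two changes cannot be separated until groups such as 4-chlorophenyl and 3-iodophenyl can be compared. All the groups shown are substituted or plain phenyl rings, which leaves open whether a carboxylic acid or an amine on the ring, or a saturated ring such as cyclohexyl in place of phenyl, would move the number further than these small steps.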